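The compounds below may be only part of what the source reports. "The series", "measured", "known", "first", "only" and "open" are said of these compounds alone.

Compound 1 `CCCC(C)Oc1ccc(C(=O)/C=C/c2c(/C=C/c3ccc(OC)cc3)cc(OC)cc2OC)cc1`: 11.1 ug/mL in a functional assay on HepG2 cells (Homo sapiens) for antiproliferative activity, read by MTT assay, with a stated time of 48 h; on this read-out lower numbers stand for stronger inhibition and higher numbers for weaker inhibition
Compound 2 `COc1ccc(/C=C/c2cc(OC)cc(OC)c2/C=C/C(=O)c2ccc(Br)cc2)cc1`: 12.9 ug/mL
Compound 3 `COc1ccc(/C=C/c2cc(OC)cc(OC)c2/C=C/C(=O)c2ccc(Cl)cc2)cc1`: 13.6 ug/mL

The three measured compounds share one core and differ only in a single group on an aromatic carbon. In this assay compound 2 gives a number that sits within the scatter of both of its neighbours: the steps of a 1.2-fold higher number from compound 1 to compound 2 (0.07 log units; within the scatter) and a 1.1-fold higher number from compound 2 to compound 3 (0.02 log units; within the scatter) are each too small to count, as is a 1.2-fold higher number from compound 1 to compound 3 (0.09 log units; within the scatter). Compound 4 `COc1ccc(/C=C/c2cc(OC)cc(OC)c2/C=C/C(=O)c2ccc(OC)cc2)cc1` keeps the same core and carries the change (methoxy in place of bromo on an aromatic carbon). The measured steps that bear on this change are the exchanges of 1-methylbutoxy for bromo, of 1-methylbutoxy for chloro and of bromo for chloro; none of them moved the number beyond the scatter. Among the measured compounds shown here, an alkoxy group in place of a halogen thus gave no real step, and methoxy in place of bromo is expected to behave alike, so the expected step of a 1.0-fold higher number from compound 2 to compound 4 (0.00 log units; within the scatter) is none beyond the scatter. Compound 4 is therefore estimated at 13 ug/mL in this assay, with a range from 7 ug/mL to 26 ug/mL.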

Compound 4, half-maximal inhibitory concentration: 4.9 ug/mL
For compound 4 the middle estimate is 2.7-fold (0.42 log units) above the measured one; the measured number lies below the stated range.
By their numbers in this assay, from the lowest: compound 4; then compounds 1, 2 and 3 (each within the scatter of the next).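

In this assay, this position, para to a large group, turns out to respond to the change: methoxy in place of the halogens gives a 2.6-fold lower number from compound 2 to compound 4 (0.42 log units; beyond the scatter) and a 2.8-fold lower number from compound 3 to compound 4 (0.44 log units; beyond the scatter). An oxygen at this position is not enough on its own, since the 1-methylbutoxy of compound 1 stayed within the scatter of both halogen compounds, whereas methyl in place of 1-methylbutyl on that same oxygen gives a 2.3-fold lower number from compound 1 to compound 4 (0.36 log units; beyond the scatter), so the group carried by the oxygen matters here. Nothing measured on these compounds accounts for this step.

The compounds shown leave open whether an ethoxy or a propoxy group would keep the lower number of compound 4, or at what chain length between methoxy and 1-methylbutoxy it is lost. They also leave open how a hydroxyl or an amino group at this position would read.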